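Substituent change on the shared core: ethyl to fluoro

The source may report more compounds than this note shows. Statements on the series, on what has been measured and on what is new or still open speak of the compounds shown alone.

Among the compounds with values here, compound 2 `CCc1ccc2nc(C(=O)Nc3c(F)cc(-c4cccc(F)c4)cc3F)c(C)c(C(=O)O)c2c1` stands lowest of the two numbers measured so far: in a functional assay on Hep 3B2 cells (Homo sapiens) for antiproliferative activity, read by MTT assay, with a stated time of 24 h, tested at 1.23 ug/mL (a higher number here means a stronger effect of the compound at the concentration tested, a lower number a weaker effect), compound 2 gives 4.52%. Its nearest neighbour is compound 1 `Cc1ccc2nc(C(=O)Nc3c(F)cc(-c4cccc(F)c4)cc3F)c(C)c(C(=O)O)c2c1`, which in this assay gives 21.3%. Within the data shown here, the only measured step, a number 16.8 percentage points lower from compound 1 to compound 2 (beyond the scatter), lies beyond the scatter. Compound 3 `Cc1c(C(=O)Nc2c(F)cc(-c3cccc(F)c3)cc2F)nc2ccc(F)cc2c1C(=O)O` is not yet measured. It differs from compound 2 in one place: fluoro in place of ethyl on an aromatic carbon. Among the measured compounds shown here, no measured step puts fluoro at this place, so the step from compound 1 to compound 2 is the only guide. That step altered the same place in the opposite sense, lengthening the chain, and the read-out fell. Taking the chain away and setting a fluoro there is expected to recover at least part of that fall. Compound 3 is therefore estimated at 15% in this assay, with a range from 0% to 35%. The expected step of a number 10.5 percentage points higher from compound 2 to compound 3 (beyond the scatter) points upward, but a single measured step gives little hold, so the range is kept wide.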

Compound 3, a percentage reported as inhibition, at one concentration (the size of the read-out at that concentration, not a potency): 2.45%
Compound 3: the middle estimate sits 12.6 percentage points above what was measured, within the range that was stated.
By their numbers in this assay, from the lowest: compounds 3 and 2 (each within the scatter of the next); then compound 1.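

In this assay, the step of a number 2.1 percentage points lower from compound 2 to compound 3 (within the scatter) shows that ethyl and fluoro cannot be told apart at this aromatic carbon, so replacing ethyl with fluoro does not recover what was lost from compound 1 to compound 2. Methyl now stands apart from both other groups, with a number 16.8 percentage points lower from compound 1 to compound 2 (beyond the scatter) and a number 18.9 percentage points lower from compound 1 to compound 3 (beyond the scatter), so among these three compounds, moving from methyl to either the longer ethyl or to fluoro goes with a lower number. Nothing at hand explains why methyl differs from the other two groups.

Going by these compounds, it remains open whether the higher number belongs to methyl alone or would also appear with other groups at this place, such as hydrogen, chloro, methoxy or an amine. All three numbers come from a single concentration, so they show a stronger or weaker effect at that concentration only and leave open whether these differences would hold at other concentrations.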